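A few compounds are considered here, and "the series" means these few. Any claim that something is new, unique, unknown or untested is made for them only; others in the source may bear on it.

Measured so far in a functional assay on MCF7 cells (Homo sapiens) for antiproliferative activity, read by MTT assay, with a stated time of 24 h; on this read-out higher numbers stand for weaker inhibition and lower numbers for stronger inhibition:
Compound 1 `CCn1c(C(=O)N[C@@H](C)C(=O)OC)ccc1C(CC)(CC)c1ccc(OCS(=O)(=O)c2ccccc2)c(C)c1` gives 43700 nM.
Compound 2 `CCN(CC)CCNC(=O)c1ccc(C(CC)(CC)c2ccc(OCS(=O)(=O)c3ccccc3)c(C)c2)n1CC` gives 4680 nM.
Compound 3 `CCn1c(C(=O)NCCO)ccc1C(CC)(CC)c1ccc(OCS(=O)(=O)c2ccccc2)c(C)c1` gives 15500 nM.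

Compound 1 stands highest of the three, with compound 3 nearest and compound 2 furthest. Compound 4 `CCn1c(C(=O)N[C@H](CO)CCO)ccc1C(CC)(CC)c1ccc(OCS(=O)(=O)c2ccccc2)c(C)c1` differs from compound 1 at the amide-type nitrogen: 3-hydroxy-1-(hydroxymethyl)propyl in place of 1-(methoxycarbonyl)ethyl on an amide-type nitrogen. Both measured steps from compound 1 replace the same 1-(methoxycarbonyl)ethyl group: a 9.3-fold lower number from compound 1 to compound 2 (0.97 log units; beyond the scatter) and a 2.8-fold lower number from compound 1 to compound 3 (0.45 log units; beyond the scatter). Compound 3 is the closer precedent: its 2-hydroxyethyl group, like 3-hydroxy-1-(hydroxymethyl)propyl, carries hydroxy and no diethylamino, and a 3.3-fold higher number from compound 2 to compound 3 (0.52 log units; beyond the scatter) shows the gap between the two entering groups. A modest downward step in this assay is therefore expected, a 2.9-fold lower number from compound 1 to compound 4 (0.46 log units; beyond the scatter). Compound 4 is estimated at 15000 nM, range 5000 nM to 45000 nM.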

Compound 4, half-maximal inhibitory concentration: 28500 nM
For compound 4 the middle estimate is 1.9-fold (0.28 log units) below the measured one; the measured number falls inside the stated range.
By their numbers in this assay, from the lowest: compound 2; then compounds 3, 4 and 1 (each within the scatter of the next, the first and the last beyond it).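

In this assay, 3-hydroxy-1-(hydroxymethyl)propyl in place of 1-(methoxycarbonyl)ethyl on the amide-type nitrogen gives a 1.5-fold lower number from compound 1 to compound 4 (0.19 log units; within the scatter), and 2-hydroxyethyl in place of hydrogen on the chain carbon bound to that nitrogen gives a 1.8-fold higher number from compound 3 to compound 4 (0.26 log units; within the scatter); neither change is resolved by this read-out. The 2-(diethylamino)ethyl group remains separated from this new group, with a 6.1-fold higher number from compound 2 to compound 4 (0.78 log units; beyond the scatter). Nothing available bears on the cause of these steps. From the compounds shown here alone, it remains open whether a primary amine, or a carboxylic acid in place of the methyl ester, would fall with compound 2 or with compound 4.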